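The compounds below may be only part of what the source reports. "The series", "measured", "known", "first", "only" and "open" are said of these compounds alone.

Three compounds share one core and differ only in what the outer aromatic ring carries. Compound 1 `O=C(O)CC/C=C\CO[C@H]1C(OCc2ccc(-c3ccc(CO)cc3)cc2)CC[C@@H]1N1CCCCCC1` bears a hydroxymethyl on that ring, and in a functional assay for antagonist activity at thromboxane A2 receptor (Rattus norvegicus) (on this read-out higher numbers stand for weaker binding and lower numbers for tighter binding), compound 1 gives 20 nM. Compound 2 `O=C(O)CC/C=C\CO[C@H]1[C@@H](OCc2ccc(-c3ccccc3CO)cc2)CC[C@@H]1N1CCCCCC1`, with its hydroxymethyl on a different aromatic carbon of the same ring and with one more stereocentre defined, gives 12.6 nM in this assay. Compound 3 `O=C(O)CC/C=C\CO[C@H]1C(OCc2ccc(-c3ccccc3)cc2)CC[C@@H]1N1CCCCCC1` carries only hydrogen there and gives 25.1 nM. Among the compounds with values here, compound 3 thus holds the highest of the three numbers, yet the one measured step that reaches it is a 1.3-fold higher number from compound 1 to compound 3 (0.10 log units; within the scatter), and its gap to compound 2 is also within the scatter, so none of the three can be set above the others.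

Compound 4 `O=C(O)CC/C=C\CO[C@H]1C(OCc2ccc(-c3ccccc3CO)cc2)CC[C@@H]1N1CCCCCC1` differs from compound 3 by hydroxymethyl in place of hydrogen on an aromatic carbon, on the ring ortho to a large group. Within the data shown here, the one measured step that bears on this, a 1.3-fold higher number from compound 1 to compound 3 (0.10 log units; within the scatter), shows that taking a hydroxymethyl off this ring left the number essentially where it was; the value of compound 2 points the same way. A step no larger than the scatter is therefore expected, a 1.7-fold lower number from compound 3 to compound 4 (0.22 log units; within the scatter). Compound 4 is estimated at 15 nM, with a likely range from 7 nM to 32 nM.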

Compound 4, dissociation constant: 6.31 nM
Beside the measured number, compound 4's estimate is 2.4-fold (0.38 log units) above it, and the stated range ends above it.
By their numbers in this assay, from the lowest: compounds 4, 2, 1 and 3 (each within the scatter of the next, the first and the last beyond it).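

In this assay, within the data shown here, a 4.0-fold lower number from compound 3 to compound 4 (0.60 log units; beyond the scatter) lies beyond the scatter, so a hydroxymethyl on this aromatic carbon, ortho to a large group, does shift the number, a shift the earlier compounds could not establish. Where the hydroxymethyl sits also counts: a 3.2-fold lower number from compound 1 to compound 4 (0.50 log units; beyond the scatter) is likewise beyond the scatter, with 2-(hydroxymethyl)phenyl in place of 4-(hydroxymethyl)phenyl, whereas a 1.3-fold higher number from compound 1 to compound 3 (0.10 log units; within the scatter) showed that the group at the other place left the number within the scatter of plain hydrogen. The remaining step, a 2.0-fold lower number from compound 2 to compound 4 (0.30 log units; within the scatter), stays within the scatter and separates nothing, so the configuration at that saturated ring carbon remains unsettled, and this pair must be read with one caution in mind: the fact that one of compounds 2 and 4 is drawn with a defined configuration and the other without, at the place where they differ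

Still open, going by these compounds, is whether the whole hydroxymethyl is needed at this place, or whether a methyl, a methoxymethyl, an aminomethyl or a carboxylic acid on the same aromatic carbon would give a similar number. Also open, on these data alone, is what each single configuration at the undefined ring carbon gives on its own, set against the opposite one.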